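The source may hold more compounds than are shown below. What is called first, only, known or untested is meant among the compounds shown, and "the series" means these compounds.

Compound 1 `O=c1cc(-c2ccccc2)oc2ccc(N3COc4c(cccc4[N+](=O)[O-])C3)cc12` carries a nitro group on the shared core. Going by the values given here, in a functional assay on MCF7 cells (Homo sapiens) for inhibition, read by MTT assay, with a stated time of 48 h, tested at 7.5 ug/mL (on this read-out lower numbers stand for less inhibition of growth and higher numbers for more inhibition of growth at the one concentration tested), compound 1 gives 8.2%, the only numerical value so far, and it sits near the low end of the read-out. Compound 2 `O=c1cc(-c2ccccc2)oc2cc(N3COc4c(cccc4[N+](=O)[O-])C3)ccc12` shares the core; in this assay compound 2 is reported as "not active" (no number reported), with no figure attached. Among the compounds with values here, no steps between measured compounds are available, so compound 1 is placed by its own value alone. Compound 3 `O=c1cc(-c2ccccc2)oc2ccc(N3COc4c(Br)cccc4C3)cc12` is the next entry: bromo in place of nitro on an aromatic carbon. With no measured comparison to draw on, the step in this assay is expected to be small, not beyond the scatter, and of no clear direction. The expected change is a number 0.2 percentage points lower from compound 1 to compound 3 (within the scatter). Compound 3 is accordingly estimated at about 8% in this assay, with a range from 0% to 20%.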

Compound 3, percent growth inhibition at one concentration: "not active" (no number reported)
Compound 3: no number reported, so the estimate cannot be set against anything.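

No new step can be read between compound 1 and compound 3: in this assay compound 1 gives 8.2% while compound 3 is reported as not active, without a number. The compounds shown leave open how far bromo in place of nitro shifts growth inhibition. No measured property bears on this result.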